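A few compounds are considered here, and "the series" means these few. Any claim that something is new, unique, unknown or untested is made for them only; others in the source may bear on it.

Compounds measured: compound 1 `COc1cc(-c2nn(-c3cccc(NC(=O)Nc4ccc(Cl)c(Cl)c4)c3)cc2-c2ccncc2)ccc1Cl` with 3700 nM and compound 2 `COc1cc(-c2nn(-c3cccc(NC(=O)Nc4cccc(C(F)(F)F)c4)c3)cc2-c2ccncc2)ccc1Cl` with 3510 nM.

In a functional assay on CAKI-1 cells (Homo sapiens) for inhibition, read by sulforhodamine B assay, with a stated time of 48 h (on this read-out higher numbers stand for weaker inhibition of growth and lower numbers for stronger inhibition of growth), compound 2 stands at the lowest of the two numbers, although compound 1 sits only a hair away, a gap a 1.1-fold lower number from compound 1 to compound 2 (0.02 log units; within the scatter) that lies within the scatter. Compound 3 `COc1cc(-c2nn(-c3cccc(NC(=O)Nc4ccc(Cl)c(C(F)(F)F)c4)c3)cc2-c2ccncc2)ccc1Cl` differs from compound 2 by chloro in place of hydrogen on an aromatic carbon. Among the compounds with values here, no measured step covers this change; the only step known, from the 3,4-dichlorophenyl to the 3-(trifluoromethyl)phenyl compound, moved nothing beyond the scatter. Compound 3 is therefore expected to give 3000 nM (range 1200 nM to 7500 nM), a step of a 1.2-fold lower number from compound 2 to compound 3 (0.07 log units; within the scatter) that would not exceed the scatter.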

Compound 3, concentration for total growth inhibition: 4720 nM
Compound 3: the middle estimate sits 1.6-fold (0.20 log units) below what was measured; measured number inside the range.
By their numbers in this assay, from the lowest: compounds 2, 1 and 3 (each within the scatter of the next).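

In this assay the change from 3-(trifluoromethyl)phenyl to 4-chloro-3-(trifluoromethyl)phenyl gave a 1.3-fold higher number from compound 2 to compound 3 (0.13 log units; within the scatter) and so left the read-out unmoved by a chloro group ortho to a trifluoromethyl group. Trifluoromethyl in place of chloro on that same ring gave a 1.3-fold higher number from compound 1 to compound 3 (0.11 log units; within the scatter) and, with the earlier step, places all three compounds within the scatter of one another. Nothing available offers a reason for this flat picture.

As far as these compounds go, whether an amine or a carboxylic acid at this place would move the number beyond the scatter remains open. So does whether any change on this ring can do so.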